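The source may hold more compounds than are shown below. What is called first, only, known or untested is meant among the compounds shown, and "the series" means these compounds.

Three compounds share one core and differ only in the group carried on the ring nitrogen. Compound 1 `CC(C)(C)C1=NN(c2ccc(F)cc2)C(c2ccc(O)cc2)C1` gives in an assay on isolated protein for inhibition of protein kinase C zeta type (Homo sapiens), with a stated time of 4 min, tested at 62.5 uM (a higher number here means more inhibition at the concentration tested (going by the name of the read-out), a lower number less inhibition), a value of 95.5%. Compound 2 `CC(C)(C)C1=NN(c2ccc(Br)cc2)C(c2ccc(O)cc2)C1` gives 93.2%, and compound 3 `CC(C)c1ccc(N2N=C(C(C)(C)C)CC2c2ccc(O)cc2)cc1` gives 54.9%. Compound 2 stands second highest of the three: its nearest neighbour is compound 1, as the step of a number 2.3 percentage points lower from compound 1 to compound 2 (within the scatter) lies within the scatter, while the step of a number 38.3 percentage points lower from compound 2 to compound 3 (beyond the scatter) is large, as is a number 40.6 percentage points lower from compound 1 to compound 3 (beyond the scatter).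

Compound 4 `CC(C)(C)C1=NN(c2cccc(Cl)c2)C(c2ccc(O)cc2)C1` has not yet been measured. Its change from compound 2 is 3-chlorophenyl in place of 4-bromophenyl on an amine nitrogen in a ring. Two things in the measured steps bear on this. Exchanging one halogen for another, as in a number 2.3 percentage points lower from compound 1 to compound 2 (within the scatter), changed nothing beyond the scatter, so chloro in place of bromo is not expected to matter much. Going by the values given here, no measured pair, however, moves the substituent to a different carbon of that phenyl ring, so that part of the change is untested. The expected step is therefore a number 6.2 percentage points lower from compound 2 to compound 4 (within the scatter), a small drop at most, and compound 4 is estimated at 87%, within a range from 65% to 98%.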

Compound 4, a percentage reported as inhibition, at one concentration (the size of the read-out at that concentration, not a potency): 96.8%
The estimate for compound 4 lay 9.8 percentage points below the measured number; the measured number falls inside the stated range.
By their numbers in this assay, from the lowest: compound 3; then compounds 2, 1 and 4 (each within the scatter of the next).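

In this assay the exchange of 4-bromophenyl for 3-chlorophenyl on the amine nitrogen gives a number 3.6 percentage points higher from compound 2 to compound 4 (within the scatter) and the exchange of 4-fluorophenyl for the same group gives a number 1.3 percentage points higher from compound 1 to compound 4 (within the scatter) on the same scale. Going by these compounds alone, this is the first measured case of a halogen on a different carbon of that phenyl ring, and the read-out does not separate it from the two earlier halogen compounds. No measurement available here explains this result.

Halogen and ring carbon changed together in compound 4, so a 4-chlorophenyl or a 3-bromophenyl group would be needed to tell the two changes apart. On these data alone, it also remains open whether the inhibition in this assay would be higher, lower or level with groups other than halogens, such as an amine or a carboxylic acid, on that phenyl ring, and whether isopropyl on the carbon used in compound 4 would match compound 3.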